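Compound 4: methoxycarbonyl added to compound 2

The compounds below may be only part of what the source reports. "The series", "measured", "known", "first", "only" and "open" are said of these compounds alone.

In an ADME assay on L132 cells (Homo sapiens) for cytotoxicity, read by MTT assay, with a stated time of 72 h (on this read-out lower numbers stand for stronger inhibition and higher numbers for weaker inhibition), compound 1 `COc1ccc(C2=C(c3cc(OC)c(OC)c(OC)c3)C(=O)CC2C)cc1C(=O)O` gives > 100 ug/mL as a limit, not a number. Compound 3 `C=CCOc1cc(C2=C(c3cc(OC)c(OC)c(OC)c3)C(=O)C(O)C2)ccc1OC` gives > 100 ug/mL as a limit too. Compound 2 `COc1ccc(C2=C(c3cc(OC)c(OC)c(OC)c3)C(=O)CC2O[SiH2]C(C)(C)C)cc1` stands only at a limit, with > 100 ug/mL as its sole entry. Compound 4 `COC(=O)c1cc(C2=C(c3cc(OC)c(OC)c(OC)c3)C(=O)CC2O[SiH2]C(C)(C)C)ccc1OC` is still unmeasured and differs from compound 2 by methoxycarbonyl in place of hydrogen on an aromatic carbon in the form of methoxycarbonyl in place of hydrogen on an aromatic carbon. Given the limit of > 100 ug/mL in this assay, at which 3 of the 3 values shown sit, as the only evidence, the expected change in this assay is none beyond the scatter, with a number no higher from compound 2 to compound 4 (the limit leaves the size open) as the estimated step. For compound 4 the estimated value is 100 ug/mL within an expected range of 50 ug/mL to 200 ug/mL as the likely span.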

Compound 4, half-maximal inhibitory concentration: > 100 ug/mL
Compound 4: only a limit was reported; the forecaster's own chance of this, stated with the estimate: 80%; the middle value sits exactly at the limit.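

No step can be read from compound 2 to compound 4: both stand only as limits. The compounds shown leave open what any change on the shared core does to a numerical value in this assay.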